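This account rests on a few compounds, and the source may have more. Where it says the series, first, only, none or still open, it means among the compounds named here.

Measured compounds and their values in the assay for total growth inhibition:

Compound 1 `ClCc1ccc(Cn2cnc3c(Cl)ncnc32)cc1` gives 6920 nM.
Compound 2 `ClCc1ccc(Cn2cnc3nc(Cl)nc(Cl)c32)cc1` gives 3460 nM.
Compound 3 `ClCc1cccc(Cn2cnc3c(Cl)nc(Cl)nc32)c1` gives 2310 nM.

In a functional assay on EKVX cells (Homo sapiens) for cytotoxicity, read by sulforhodamine B assay, with a stated time of 48 h (on this read-out lower numbers stand for stronger inhibition of growth and higher numbers for weaker inhibition of growth), compound 2 stands second highest of the three numbers; its nearest neighbour, compound 3, and its furthest, compound 1, both lie within the scatter of it, so no order among the three can be claimed. Compound 4 `ClCc1ccc(Cn2cnc3ncnc(Cl)c32)cc1` has not yet been measured. It differs from compound 2 by hydrogen in place of chloro on an aromatic carbon. Among the measured compounds shown here, no measured pair shows a step of this kind, so the direction is open; a step of modest size, toward a higher number or none beyond the scatter, is expected. For compound 4 the estimate is 6000 nM, with a range from 2500 nM to 14000 nM, meaning an expected step of a 1.7-fold higher number from compound 2 to compound 4 (0.24 log units; within the scatter).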

Compound 4, concentration for total growth inhibition: 4460 nM
The estimate for compound 4 lay 1.3-fold (0.13 log units) above the measured number; the range from low to high includes it.
By their numbers in this assay, from the lowest: compounds 3, 2, 4 and 1 (each within the scatter of the next, the first and the last beyond it).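

In this assay, hydrogen in place of chloro on the aromatic carbon between two ring nitrogen atoms gives a 1.3-fold higher number from compound 2 to compound 4 (0.11 log units; within the scatter). Among the compounds shown here, this is the only comparison here of compounds that differ in one place, and it shows that losing this chloro group leaves the number within the scatter. Nothing available explains this result. Still open, going by these compounds, is whether an amine or a methoxy group on this carbon would move the number beyond the scatter. Also open, on these data alone, is whether the same change would read alike on the core of compound 3.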